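Sulfonamide in place of the aminoacetamide chain: working note

The source may hold more compounds than are shown below. What is called first, only, known or untested is meant among the compounds shown, and "the series" means these compounds.

Measured so far:
compound 1, `CNCC1CCCc2cc(S(=O)(=O)c3ccccc3)ccc21`: 0.316 nM
compound 2, `NC(=O)CNC[C@@H]1CCCc2cc(S(=O)(=O)c3cccc(F)c3)ccc21`: 0.1 nM

In an assay on isolated protein for displacement of a labelled ligand from 5-hydroxytryptamine receptor 6 (Homo sapiens) (a higher number here means a weaker inhibitor, a lower number a stronger inhibitor), compound 2 gives the lower of the two numbers; the gap to compound 1 is beyond the usual scatter, so compound 2 stands as the stronger of the two measured compounds, and it is the reference for the step considered here.

Compound 3, `CN(C[C@@H]1CCCc2cc(S(=O)(=O)c3cccc(F)c3)ccc21)S(C)(=O)=O`, has not yet been measured in this assay. It is derived from compound 2 by a single change: methyl(methylsulfonyl)amino in place of (carbamoylmethyl)amino on a saturated chain carbon bound to a saturated ring carbon. The group that leaves carries hydrogen-bond donors; the group that enters carries none, with the acceptor count unchanged.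

Among the measured compounds shown here, no step of this kind between measured compounds is on record, so the expectation rests on the change itself and on the value of compound 2 alone. The step from compound 2 to compound 3 is expected to raise the number, giving a 30-fold higher number from compound 2 to compound 3 (1.48 log units; beyond the scatter), clearly beyond the scatter, though with wide uncertainty in either direction. Compound 3 is estimated at 3 nM, with a range from 0.4 nM to 30 nM.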

Compound 3, inhibition constant: 0.398 nM
Estimate against measurement, compound 3: 7.5-fold (0.88 log units) above, and the stated range ends above it.
By their numbers in this assay, from the lowest: compound 2; then compounds 1 and 3 (each within the scatter of the next).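

In this assay, methyl(methylsulfonyl)amino in place of (carbamoylmethyl)amino on a saturated chain carbon bound to a saturated ring carbon gives a 4.0-fold higher number from compound 2 to compound 3 (0.60 log units; beyond the scatter), a modest step beyond the scatter, and compound 3 still reads 0.398 nM. Among the compounds shown here, this is the first sign that the position tolerates a substantial change of group: the entering group has no hydrogen-bond donors and contains sulfur, yet the number rises only modestly, so the donors of the leaving group are not required for a low number, though their absence may still contribute to the step. Nothing measured on these compounds explains the size of the step, which therefore remains a plain observation.

Still open, going by these compounds, is whether the sulfonyl part or the methyl on the nitrogen matters more here, a question that a methyl(acetyl)amino group or a plain primary amine at the same place would help to settle. Compound 1 differs from compound 2 and from compound 3 in more than one place, so those steps cannot be read, and the contribution of the fluorine remains unresolved.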